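The compounds below may be only part of what the source reports. "The series", "measured", "known", "first", "only" and "open" are said of these compounds alone.

Working notes on the series.

Compound 1 `COc1ccc2c(c1)c(S(=O)(=O)c1cccc(F)c1)cn2C1CCCNC1` carries a piperidin-3-yl group on the shared core. In an assay on HeLa cells for displacement of a labelled ligand from 5-hydroxytryptamine receptor 6 (Homo sapiens), with a stated time of 2 h (a lower number here means a stronger inhibitor, a higher number a weaker inhibitor), compound 1 gives 10.7 nM. Compound 2 `COc1ccc2c(c1)c(S(=O)(=O)c1cccc(F)c1)cn2C1CCCN(C)C1` differs from compound 1 by the change (methyl in place of hydrogen on an amine nitrogen in a ring); in this assay compound 2 gives 68 nM. Within the data shown here, the step of a 6.4-fold higher number from compound 1 to compound 2 (0.80 log units; beyond the scatter) is the only measured instance of this change so far.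

Compound 3 `O=S(=O)(c1cccc2ccccc12)c1cn(C2CCCNC2)c2ccccc12` has a different core; the difference between the core of compound 3 and the core of compound 1 is not broken down here. In this assay compound 3 gives 21 nM, which lies within the usual scatter of the number for compound 1, so no order between compound 1 and compound 3 is claimed. Compound 3 does stand beyond the scatter from compound 2.

Compound 4 `CN1CCCC(n2cc(S(=O)(=O)c3cccc4ccccc34)c3ccccc32)C1` is not yet measured. It differs from compound 3 by methyl in place of hydrogen on an amine nitrogen in a ring, the same change, in the same place, as that from compound 1 to compound 2. Among the measured compounds shown here, the expectation for compound 4 rests on the single measured instance of this change, the step of a 6.4-fold higher number from compound 1 to compound 2 (0.80 log units; beyond the scatter), applied to compound 3. The step from compound 3 to compound 4 in this assay is therefore expected to be about a 6.2-fold higher number from compound 3 to compound 4 (0.79 log units; beyond the scatter). For the measured compounds named here, on that basis compound 4 is estimated to give 130 nM in this assay, with a range from 45 nM to 380 nM, the range being wide because only one prior step, a 6.4-fold higher number from compound 1 to compound 2 (0.80 log units; beyond the scatter), supports the expectation and it was measured on a different core.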

Compound 4, inhibition constant: 7.1 nM
Estimate against measurement, compound 4: 18-fold (1.26 log units) above; measured number outside the range, below it.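

In this assay, among these compounds, going from piperidin-3-yl to 1-methylpiperidin-3-yl on the core of compound 3 gives a 3.0-fold lower number from compound 3 to compound 4 (0.47 log units; beyond the scatter) and so moves the number the opposite way from the one earlier instance of this change, on the core of compound 1. The effect of methyl in place of hydrogen on an amine nitrogen in a ring therefore does not carry from one core to the other in this series, in size or in direction: the same change on two cores in this assay, a 6.4-fold higher number (0.80 log units; beyond the scatter) from compound 1 to compound 2 and a 3.0-fold lower number (0.47 log units; beyond the scatter) from compound 3 to compound 4, 19-fold (1.27 log units) apart, beyond the scatter of two such steps. This shows that the step depends on the core it is made on, but it does not show which part of the difference between the two cores is responsible, and two instances give no rule for predicting the step on any further core.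

The compounds shown leave open whether a longer chain such as ethyl, or an acyl group such as acetyl, on the same ring nitrogen would follow the direction of methyl on each core. They also leave open which direction the methyl step would take on a core that differs from the core of compound 1 or the core of compound 3 in one place only.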